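Quinoxaline diamines with aryl ether and thioether substituents

The source may report more compounds than this note shows. Statements on the series, on what has been measured and on what is new or still open speak of the compounds shown alone.

Compound 1: `Nc1cc(N)c2nc(-c3ccccc3)c(Oc3ccc(Cl)c(Cl)c3)nc2c1` — < 100000 nM
Compound 2: `Nc1cc(N)c2nc(-c3ccccc3)c(Sc3ccc(F)cc3)nc2c1` — < 100000 nM
Compound 3: `Nc1cc(N)c2nc(-c3ccccc3)c(Oc3ccc(F)cc3)nc2c1` — < 100000 nM

Three compounds share a core carrying two amino groups and a phenyl group. In a functional assay on SK-MEL-28 cells (Homo sapiens) for inhibition, read by sulforhodamine B assay, with a stated time of 48 h (a higher number here means that more compound is tolerated, a lower number that less compound is tolerated), compound 1 reports only a limit of the assay, < 100000 nM. In this assay compound 2 likewise reports only a limit, < 100000 nM. In this assay compound 3 also stands at a limit rather than a number, < 100000 nM. All three therefore sit at the same place, as the evidence states: the limit of < 100000 nM in this assay, at which 3 of the 3 values shown sit.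

The steps between them are accordingly unreadable: a step that the two limits leave unreadable from compound 1 to compound 2, a step that the two limits leave unreadable from compound 1 to compound 3 and a step that the two limits leave unreadable from compound 2 to compound 3. None of them gives a size or a direction.

Compound 4 is `Nc1cc(N)c2nc(-c3ccccc3)c(Sc3ccc(Cl)c(Cl)c3)nc2c1`, not yet measured. It differs from compound 3 as follows: (3,4-dichlorophenyl)sulfanyl in place of 4-fluorophenoxy on an aromatic carbon. Going by the values given here, the change combines the two features already seen separately in compound 1 and compound 2, both of which stand at the same limit as compound 3, so no measured step bears readably on it.

Compound 4 is therefore expected to stand at about 30000 nM in this assay, within 5000 nM to 100000 nM, most probably again reported as a limit. The estimated step that the limit leaves unreadable from compound 3 to compound 4 is expected to be no larger than the scatter.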

Compound 4, concentration lethal to 50% of the cells: < 100000 nM
Compound 4 gave a limit, no number (the forecaster's own chance of this, stated with the estimate: 65%); the middle value lies beyond the limit too.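

Compound 4 also reports only a limit in this assay, so its steps to compound 1, compound 2 and compound 3 cannot be read in size or direction: the limit of < 100000 nM in this assay, at which 4 of the 4 values shown sit.

The four compounds leave open whether exchanging oxygen for sulfur, or 4-fluorophenyl for 3,4-dichlorophenyl, changes the result in this assay at all.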